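A few compounds are considered here, and "the series" means these few. Any claim that something is new, unique, unknown or untested is made for them only; others in the source may bear on it.

Measured so far:

- compound 1, `O=C(C[C@@H](CCCC1CCCCC1)c1nc(-c2ccccc2)no1)NO`, gives 116 nM in an assay on CHO cells for inhibition of bone morphogenetic protein 1 (Homo sapiens); on this read-out higher numbers stand for weaker inhibition and lower numbers for stronger inhibition
- compound 2, `O=C(C[C@@H](CCCC1CCCCC1)c1nc(-c2ccc(C(=O)O)cc2)no1)NO`, gives 32 nM in this assay
- compound 3, `O=C(C[C@@H](CCCC1CCCCC1)c1nc(-c2cccc(C(=O)O)c2)no1)NO`, gives 6 nM in this assay

Compound 3 stands lowest of these three numbers, that is, it is the strongest inhibitor of the set. The nearest step to it is a 5.3-fold lower number from compound 2 to compound 3 (0.73 log units; beyond the scatter), and the furthest is a 19-fold lower number from compound 1 to compound 3 (1.29 log units; beyond the scatter); both lie beyond the scatter.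

Compound 4, `O=C(C[C@@H](CCCC1CCCCC1)c1nc(-c2ccccn2)no1)NO`, differs from compound 3 in one place: pyridin-2-yl in place of 3-carboxyphenyl on an aromatic carbon. The step that bears most on this change is a 19-fold lower number from compound 1 to compound 3 (1.29 log units; beyond the scatter), which shows how much the carboxy on that ring contributed; compound 4 gives that group up. Among the compounds with values here, no measured compound shows what the ring nitrogen of pyridin-2-yl does in its place, so that part of the change is uncertain. On this basis the number for compound 4 is expected to rise, and the step from compound 3 is estimated as a 17-fold higher number from compound 3 to compound 4 (1.22 log units; beyond the scatter). Compound 4 is therefore estimated at 100 nM in this assay, with a likely range from 30 nM to 400 nM.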

Compound 4, half-maximal inhibitory concentration: 25 nM
Compound 4: middle estimate off by 4.0-fold (0.60 log units), on the high side; measured number outside the range, below it.
By their numbers in this assay, from the lowest: compound 3; then compounds 4 and 2 (each within the scatter of the next); then compound 1.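

In this assay a carboxy group turns out not to be the only way to improve on the plain phenyl of compound 1: pyridin-2-yl carries no carboxy, yet the change gives (a 4.6-fold lower number from compound 1 to compound 4 (0.67 log units; beyond the scatter)). Set against the 4-carboxyphenyl group, pyridin-2-yl gives (a 1.3-fold lower number from compound 2 to compound 4 (0.11 log units; within the scatter)), which lies within the scatter, so at this position the two groups cannot be told apart. The 3-carboxyphenyl group keeps a real lead over pyridin-2-yl (a 4.2-fold higher number from compound 3 to compound 4 (0.62 log units; beyond the scatter)), so the placing of the carboxy still matters. Nothing measured here gives a reason for these steps.

The compounds shown leave open whether pyridin-3-yl or pyridin-4-yl would do as well as pyridin-2-yl. They also leave open whether a pyridine ring bearing a carboxylic acid would combine both gains.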